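The source may report more compounds than this note shows. Statements on the series, on what has been measured and on what is new or still open speak of the compounds shown alone.

Series notes. Compound 1 `CC(=O)c1ccc(-c2ccc(OCc3cc(C(=O)O)oc3C)cc2)cc1` gives 150 nM in an assay on cells for displacement of a labelled ligand from prostaglandin E2 receptor EP4 subtype (Homo sapiens), read by scintillation counting; a higher number here means a weaker inhibitor, a lower number a stronger inhibitor. Compound 2 `Cc1oc(C(=O)O)cc1COc1ccc(-c2ccc(CO)cc2)cc1` gives 3000 nM in this assay, and compound 3 `Cc1oc(C(=O)O)cc1COc1ccc(-c2ccc(C#N)cc2)cc1` gives 1500 nM. Among these three numbers compound 3 stands second highest; its nearest neighbour is compound 2, a gap within the scatter, and its furthest is compound 1, a gap beyond it. The steps among the three are a 20-fold higher number from compound 1 to compound 2 (1.30 log units; beyond the scatter), a 10-fold higher number from compound 1 to compound 3 (1.00 log units; beyond the scatter) and a 2.0-fold lower number from compound 2 to compound 3 (0.30 log units; within the scatter).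

Compound 4 `Cc1oc(C(=O)O)cc1COc1ccc(-c2ccncc2)cc1` is not yet measured; it differs from compound 3 by pyridin-4-yl in place of 4-cyanophenyl on an aromatic carbon. The three measured steps all exchange the group on an aromatic carbon of the outer ring and none removes that ring, so none bears directly on this change; the nearest in kind, between compound 2 and compound 3, lies within the scatter. Nothing here points to a gain, so the expected step is a 2.0-fold higher number from compound 3 to compound 4 (0.30 log units; within the scatter), possibly no larger than the scatter. Compound 4 is therefore estimated at 3000 nM in this assay, within 800 nM to 12000 nM.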

Compound 4, inhibition constant: > 10000 nM
Compound 4: no number, only a limit; the forecaster's own chance of this, stated with the estimate: 10%; middle value at least 3.3-fold (0.52 log units) away from the limit.
By their numbers in this assay, from the lowest: compound 1; then compounds 3 and 2 (each within the scatter of the next). At a limit, above all of these: compound 4.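

The value for compound 4 is a limit and not a number: the limit of > 10000 nM in this assay, at which 1 of the 4 values shown sits. In this assay, pyridin-4-yl in place of the substituted phenyl gives an at least 6.6-fold higher number from compound 3 to compound 4 (0.82 log units; beyond the scatter), and likewise an at least 3.3-fold higher number from compound 2 to compound 4 (0.52 log units; beyond the scatter); both steps are beyond the scatter and give only a minimum size. The earlier steps shown here exchanged only the group carried on a carbon-only ring, whereas this change replaces the ring and its group together, and it shows that this position does not accept that exchange without a loss of binding that exceeds the scatter.

The compounds shown leave open whether the ring nitrogen or the absence of the outer group accounts for the loss. Plain phenyl at this position would separate the two, and an acetyl group on the pyridine ring would test whether acetyl restores binding there.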